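Side-chain change from compound 3 to compound 4

The compounds below may be only part of what the source reports. "The series", "measured", "known", "first", "only" and "open" are said of these compounds alone.

In a functional assay on B16-F10 cells (Mus musculus) for antiproliferative activity, read by CCK-8 assay, with a stated time of 48 h (on this read-out lower numbers stand for stronger inhibition and higher numbers for weaker inhibition), compound 1 `COc1ccc(/C=C\c2cc(OC)c(OC)c(OC)c2)cc1OCc1ccc(CN2CCCC[C@H]2C(=O)O)cc1` gives > 10000 nM as a limit of the assay. Compound 2 `COc1ccc(/C=C\c2cc(OC)c(OC)c(OC)c2)cc1OCc1ccc(CN2CCCCC2C(=O)O)cc1` likewise gives > 10000 nM as a limit. In this assay, going by the values given here, compound 3 `COc1ccc(/C=C\c2cc(OC)c(OC)c(OC)c2)cc1OCc1ccc(CNCCO)cc1` gives 6600 nM and holds the only number of the three. Compound 4 `COc1ccc(/C=C\c2cc(OC)c(OC)c(OC)c2)cc1OCc1ccc(CNCCNC(C)=O)cc1` carries acetamido in place of hydroxy on a saturated chain carbon, two bonds along the chain from an amine nitrogen as its change from compound 3: acetamido in place of hydroxy on a saturated chain carbon, two bonds along the chain from an amine nitrogen. Among the compounds with values here, no measured step touches that hydroxy. The nearest are an at least 1.5-fold lower number from compound 1 to compound 3 (0.18 log units; that floor lies within the scatter) and an at least 1.5-fold lower number from compound 2 to compound 3 (0.18 log units; that floor lies within the scatter) and both remain floors within the scatter. Resting on compound 3 at 6600 nM and those floors, no step beyond the scatter is expected in this assay for this change. The estimated step is a 1.1-fold higher number from compound 3 to compound 4 (0.03 log units; within the scatter) in size. Compound 4 is estimated at 7000 nM with an expected range from 2500 nM to 15000 nM around it.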

Compound 4, half-maximal inhibitory concentration: 2500 nM
Compound 4: the middle estimate sits 2.8-fold (0.45 log units) above what was measured; the range from low to high includes it.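

In this assay, going by these compounds alone, the change from hydroxy to acetamido gives a 2.6-fold lower number from compound 3 to compound 4 (0.42 log units; beyond the scatter), the first step at this position that clears the scatter. The replacement of 2-carboxypiperidin-1-yl by (2-acetamidoethyl)amino gives an at least 4.0-fold lower number from compound 2 to compound 4 (0.60 log units; beyond the scatter) and an at least 4.0-fold lower number from compound 1 to compound 4 (0.60 log units; beyond the scatter); unlike the floors for compound 3, both lie beyond the scatter, though they remain floors set by assay limits.

Nothing shown explains why acetamido gives the lower number. From the compounds shown here alone, whether a longer chain, a primary amine or a carboxylic acid at this place would keep the step remains open.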